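The compounds below may be only part of what the source reports. "The series", "measured", "known", "first", "only" and "open" are said of these compounds alone.

Compound 1, `COC[C@@H](C)[C@H](C)C(c1ccc(O)c(OC)c1)c1ccc(O)c(OC)c1`, gives 73000 nM in a functional assay on HL-60 cells (Homo sapiens) for cytotoxicity, read by WST assay, with a stated time of 48 h; a higher number here means a weaker inhibitor, a lower number a stronger inhibitor. Compound 2, `COc1cc(C(c2ccc(O)c(OC)c2)[C@H](C)[C@H](C)CO)ccc1O`, gives only a limit in this assay, > 100000 nM.

Compound 2 thus sits at the limit of > 100000 nM in this assay, at which 1 of the 2 values shown sits, with no number of its own. Compound 3, `CC[C@H](C(C)C)C(c1ccc(O)c(OC)c1)c1ccc(O)c(OC)c1`, is not yet measured; it differs from compound 2 by 1-isopropylpropyl in place of 2-(hydroxymethyl)-1-methylpropyl on a saturated chain carbon bound to two aromatic carbons. Within the data shown here, the only measured step at that position is an at least 1.3-fold higher number from compound 1 to compound 2 (0.13 log units; that floor lies within the scatter), a floor that lies within the scatter, and it concerns a different pair of groups. The step of an at least 1.4-fold lower number from compound 2 to compound 3 (0.15 log units; that floor lies within the scatter) is therefore expected to be modest and uncertain. Compound 3 is expected to give 70000 nM, between 20000 nM and 200000 nM.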

Compound 3, half-maximal inhibitory concentration: 16000 nM
Beside the measured number, compound 3's estimate is 4.4-fold (0.64 log units) above it; the whole stated range lies above it.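

The earlier compounds shown here gave only a floor within the scatter at this position. With the all-carbon 1-isopropylpropyl in place of either oxygen-bearing chain, the change goes beyond the scatter, as shown by a 4.6-fold lower number from compound 1 to compound 3 (0.66 log units; beyond the scatter) and by an at least 6.2-fold lower number from compound 2 to compound 3 (0.79 log units; beyond the scatter). The second of these steps is only a floor, as compound 2 gives a limit and not a number: the limit of > 100000 nM in this assay, at which 1 of the 3 values shown sits. Whether the loss of oxygen alone accounts for the change remains open. So does how an amine, a carboxylic acid or a longer unbranched carbon chain at this position would read in this assay.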